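A few compounds are considered here, and "the series" means these few. Any claim that something is new, unique, unknown or untested is made for them only; others in the source may bear on it.

Compound 1 `CN1CCN(c2ccc3[nH]nc(S(=O)(=O)c4ccc(F)cc4)c3c2)CC1` gives 467 nM. Compound 2 `CN1CCN(c2cccc3c(S(=O)(=O)c4cccc5ccccc45)n[nH]c23)CC1` gives 17 nM. Compound 3 `Cn1nc(S(=O)(=O)c2ccccc2)c2cc(N3CCNCC3)ccc21` gives 3.2 nM.

All three values come from a functional assay on HeLa cells for antagonist activity at 5-hydroxytryptamine receptor 6 (Homo sapiens) (a lower number here means a stronger inhibitor, a higher number a weaker inhibitor), and among them compound 1 stands at the highest number, making it the weakest inhibitor of the three: compound 2 lies well below it, and compound 3 lower still, both gaps beyond the scatter.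

Compound 4 `Cc1ccc(S(=O)(=O)c2n[nH]c3ccc(N4CCN(C)CC4)cc23)cc1` has not been measured. It differs from compound 1 in one place: methyl in place of fluoro on an aromatic carbon. Going by the values given here, no pair of measured compounds isolates this change, and compounds 2 and 3 differ from compound 1 in several other places, so they offer no direct guide. The expected step of a 1.3-fold lower number from compound 1 to compound 4 (0.13 log units; within the scatter) is small, not beyond the scatter. Compound 4 is therefore estimated at 350 nM, with a range from 120 nM to 1000 nM.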

Compound 4, half-maximal inhibitory concentration: 112 nM
Beside the measured number, compound 4's estimate is 3.1-fold (0.49 log units) above it; the measured number lies below the stated range.
By their numbers in this assay, from the lowest: compound 3; then compound 2; then compound 4; then compound 1.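

In this assay, putting methyl in place of fluoro on the aromatic ring gives a 4.2-fold lower number from compound 1 to compound 4 (0.62 log units; beyond the scatter), so compound 4 is the stronger inhibitor of this pair. Going by these compounds alone, this is the first direct reading of this position: a change of one heavy atom, from 4-fluorophenyl to 4-methylphenyl, is enough to move the number beyond the usual scatter. No measurement shown here explains the shift.

On these data alone, whether ethyl, methoxy or an amine at this place would lower the number further remains open. So does whether the same swap would have a similar effect on a different core.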